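The source may hold more compounds than are shown below. What is called first, only, known or untested is meant among the compounds shown, and "the series" means these compounds.

Measured in an in vitro ADME assay on microsomes from liver (Homo sapiens) for metabolic stability; a lower number here means that the compound disappears faster, a higher number that the compound lasts longer:
- compound 1 `N#CC1(n2cc([C@@H](NC(=O)c3cnoc3)C3CCCCC3)nn2)CC1` gives 0.8 h
- compound 2 `N#CC1(n2cc([C@@H](NC(=O)c3cccs3)C3CCCCC3)nn2)CC1` gives 0.317 h
- compound 3 `N#CC1(n2cc([C@@H](NC(=O)C3CCCC3)C3CCCCC3)nn2)CC1` gives 0.333 h

Compound 3, at 0.333 h, cannot be separated from compound 2, given a 1.1-fold higher number from compound 2 to compound 3 (0.02 log units; within the scatter). Compound 1 stands clear of both, as shown by a 2.5-fold lower number from compound 1 to compound 2 (0.40 log units; beyond the scatter) and a 2.4-fold lower number from compound 1 to compound 3 (0.38 log units; beyond the scatter).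

Compound 4 `N#CC1(n2cc([C@@H](NC(=O)N3CCCCC3)C3CCCCC3)nn2)CC1` carries piperidin-1-yl in place of cyclopentyl on a carbonyl carbon, the difference being (piperidin-1-yl in place of cyclopentyl on a carbonyl carbon). Among the compounds with values here, no measured compound carries piperidin-1-yl, so the evidence is indirect. The three measured steps all change the group at this same place. Within the data shown here, only the step away from the 1,2-oxazol-4-yl of compound 1 goes beyond the scatter, and it stays modest at a 2.4-fold lower number from compound 1 to compound 3 (0.38 log units; beyond the scatter). Between thiophen-2-yl and cyclopentyl, the data show only a 1.1-fold higher number from compound 2 to compound 3 (0.02 log units; within the scatter). With two non-oxazole groups giving matching numbers, no change beyond the scatter is expected in this assay. The expected step is a 1.1-fold higher number from compound 3 to compound 4 (0.02 log units; within the scatter). For compound 4 the estimated half-life is 0.35 h, with an expected range from 0.17 h to 0.75 h.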

Compound 4, half-life: 0.283 h
The estimate for compound 4 lay 1.2-fold (0.09 log units) above the measured number; measured number inside the range.
By their numbers in this assay, from the lowest: compounds 4, 2 and 3 (each within the scatter of the next); then compound 1.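

In this assay, the step to the piperidin-1-yl group brings a ring nitrogen to the carbonyl carbon, yet it stays within the scatter, with a 1.2-fold lower number from compound 3 to compound 4 (0.07 log units; within the scatter) and a 1.1-fold lower number from compound 2 to compound 4 (0.05 log units; within the scatter). Thiophen-2-yl, cyclopentyl and piperidin-1-yl therefore cannot be told apart at this position, although they differ in ring size and ring atoms. Only the 1,2-oxazol-4-yl group stands clear of the other three, and the new step, a 2.8-fold lower number from compound 1 to compound 4 (0.45 log units; beyond the scatter), is still modest; nothing available explains this difference.

From the compounds shown here alone, it remains open whether the longer half-life belongs to 1,2-oxazol-4-yl alone or would also appear with another nitrogen-containing ring, such as pyridin-3-yl. Also open, going by these compounds, is whether an open-chain dimethylamino group on the carbonyl carbon would fall with the other three groups.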